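This account rests on a few compounds, and the source may have more. Where it says the series, first, only, none or still open, it means among the compounds named here.

Compound 1, `CC(C)[C@@H](NS(=O)(=O)Cc1ccccc1)C(=O)N1CCC[C@H]1C(=O)NCc1ccc(C(=N)N)cc1`, gives 76 nM in an assay on isolated protein for inhibition of transmembrane protease serine 11D (Homo sapiens), read by fluorescence; a higher number here means a weaker inhibitor, a lower number a stronger inhibitor.
Compound 2, `CC(C)N1CCN(C(=O)C[C@@H](NS(=O)(=O)Cc2ccccc2)C(=O)N2CCC[C@H]2C(=O)NCc2ccc(C(=N)N)cc2)CC1`, gives 221 nM in this assay.
Compound 3, `CCC[C@H](NCc1ccc(C(=N)N)cc1)C(=O)[C@@H](CCCNC(=N)N)NS(=O)(=O)Cc1ccccc1`, gives 15 nM in this assay.

Compound 3 stands lowest of the three numbers, that is, as the strongest inhibitor shown. Its nearest neighbour is compound 1, whose number is higher by a gap that exceeds the scatter, and compound 2 lies further away still.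

Compound 4, `CC(C)C[C@H](NCc1ccc(C(=N)N)cc1)C(=O)[C@@H](CCCNC(=N)N)NS(=O)(=O)Cc1ccccc1`, has not yet been measured. It differs from compound 3 in one place: methyl in place of hydrogen on a saturated chain carbon bound to two saturated chain carbons. Among the measured compounds shown here, the only measured step, a 2.9-fold higher number from compound 1 to compound 2 (0.46 log units; beyond the scatter), concerns a much larger group at a different place, so it does not speak to a single added methyl on a chain. Compounds 1 and 3 differ in several places at once, so their two values give no guidance either. For the measured compounds named here, with no comparable step, the expectation is that the change from compound 3 to compound 4 stays small. The expected step is no change at the digits printed from compound 3 to compound 4 (within the scatter), with no clear direction beyond the scatter. Compound 4 is therefore estimated to give 15 nM in this assay, most likely between 6 nM and 40 nM.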

Compound 4, inhibition constant: 47 nM
Beside the measured number, compound 4's estimate is 3.1-fold (0.50 log units) below it, outside the stated range (above it).
By their numbers in this assay, from the lowest: compound 3; then compounds 4 and 1 (each within the scatter of the next); then compound 2.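

This change is small, with one carbon entering, yet it turns propyl into isobutyl and in this assay gives a 3.1-fold higher number from compound 3 to compound 4 (0.50 log units; beyond the scatter), so this position, on a saturated chain carbon bound to two saturated chain carbons, does respond to a single added methyl, and the response is towards a weaker inhibitor. The only earlier step, a 2.9-fold higher number from compound 1 to compound 2 (0.46 log units; beyond the scatter), brought in a much larger group at a different place and is of similar size, so among these compounds the size of the group that enters does not by itself set the size of the step. The data at hand offer nothing that explains the loss seen with the added methyl.

As far as these compounds go, two chains at this position cannot show a trend, so it remains open how an ethyl or butyl chain, or a chain ending in an amine or a carboxylic acid, would compare with propyl. From the compounds shown here alone, it also remains open whether the same added methyl would have a similar effect on a different core.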